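A few compounds are considered here, and "the series" means these few. Any claim that something is new, unique, unknown or untested is made for them only; others in the source may bear on it.

Measured compounds in an assay on membranes from HeLa cells for displacement of a labelled ligand from adenosine receptor A3 (Homo sapiens), read by scintillation counting, with a stated time of 180 min, tested at 1 uM; on this read-out lower numbers stand for less inhibition and higher numbers for more inhibition at the one concentration tested (going by the name of the read-out):

compound 1, `CC1=C(C(=O)OCc2ccccc2)C(c2ccco2)NC(=O)N1` — compound 1 gives 3%
compound 2, `CC1=C(C(=O)OCc2ccccc2)C(c2cccs2)NC(=O)N1` — compound 2 gives 8%
compound 3, `CCCOC(=O)C1=C(C)NC(=S)NC1c1ccco1` — compound 3 gives 1%

Compound 3 shows the lowest of the three numbers, yet its gaps to compound 1 and to compound 2 both lie within the scatter of this assay, so no order among the three can be read from these values. Going by the values given here, the only measured step, a number 5 percentage points higher from compound 1 to compound 2 (within the scatter), swaps the aryl group on the saturated ring carbon and stays within the scatter as well.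

Compound 4, `CC1=C(C(=O)OCC(C)C)C(c2ccco2)NC(=S)N1`, is not yet measured in this assay. Against compound 3 it differs by methyl in place of hydrogen on a saturated chain carbon bound to two saturated chain carbons; taken one bond further out, the ester chain goes from propoxy to isobutoxy. Among the compounds with values here, no measured pair touches the ester chain, so nothing among the measured steps bears directly on this change; the one measured step concerns a different position and was itself within the scatter. The three measured values all sit close to the bottom of the scale, and the change here is small in count. The expected step of a number 2 percentage points higher from compound 3 to compound 4 (within the scatter) is therefore none beyond the scatter. Compound 4 is estimated at 3%, with a range from -5% to 12%.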

Compound 4, a percentage reported as inhibition, at one concentration (the size of the read-out at that concentration, not a potency): 10%
The estimate for compound 4 lay 7 percentage points below the measured number; the measured number falls inside the stated range.
By their numbers in this assay, from the lowest: compounds 3, 1, 2 and 4 (each within the scatter of the next).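

The ester chain now has its first measured pair: in this assay, going from propoxy to isobutoxy, with methyl in place of hydrogen on a saturated chain carbon bound to two saturated chain carbons, gives a number 9 percentage points higher from compound 3 to compound 4 (within the scatter). Going by these compounds alone, at this position, then, the added methyl has no effect that can be told apart from the scatter, and a single-concentration read-out gives no potency for either compound. Nothing available offers an explanation for this step.

This one pair does not settle whether the ester chain matters more widely: a longer chain such as hexyl, or a carboxylic acid in place of the ester, could still move the number beyond the scatter. From the compounds shown here alone, it also remains open whether a branch placed elsewhere on the ester chain, or an amine at its end, would give a step of a different size in this assay.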